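A Dimethoxyphenyl Swap on Compound 3

The compounds below may be only part of what the source reports. "The series", "measured", "known", "first", "only" and "open" are said of these compounds alone.

In a functional assay on HCT-116 cells (Homo sapiens) for antiproliferative activity, read by sulforhodamine B assay, with a stated time of 48 h (on this read-out higher numbers stand for weaker inhibition and lower numbers for stronger inhibition), compound 1 (`COc1cc(O)c(C(=O)/C=C/c2ccc(OC)c(OC)c2)c(OC)c1`) gives 27600 nM and compound 2 (`COc1cc(O)c(C(=O)/C=C/c2cccc(Cl)c2Cl)c(OC)c1`) gives 2700 nM as its number. Compound 3 (`COc1ccc(/C=C/C(=O)c2c(OC)cc(OC)cc2OCC=C(C)C)cc1`) gives 7600 nM and so sits in the middle of the three, with both gaps beyond the scatter. Compound 4 (`COc1cc(OC)c(C(=O)/C=C/c2cccc(OC)c2OC)c(OCC=C(C)C)c1`) departs from compound 3 in one place (2,3-dimethoxyphenyl in place of 4-methoxyphenyl on a double-bonded chain carbon bound to a double-bonded chain carbon), with 2,3-dimethoxyphenyl in place of 4-methoxyphenyl on a double-bonded chain carbon bound to a double-bonded chain carbon. Among the measured compounds shown here, no measured pair differs in one place only, so the size of this step remains uncertain. In this assay no step beyond the scatter is expected. The expected step (a 1.3-fold lower number from compound 3 to compound 4 (0.10 log units; within the scatter)) is small. For compound 4 a value of 6000 nM is estimated, with 2000 nM to 20000 nM as the expected range.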

Compound 4, half-maximal inhibitory concentration: 11700 nM
For compound 4 the middle estimate is 2.0-fold (0.29 log units) below the measured one; low and high end bracket the measured number.
By their numbers in this assay, from the lowest: compound 2; then compounds 3 and 4 (each within the scatter of the next); then compound 1.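

In this assay, among the compounds shown here, the exchange of 4-methoxyphenyl for 2,3-dimethoxyphenyl gives a 1.5-fold higher number from compound 3 to compound 4 (0.19 log units; within the scatter) and is the first single-place comparison in this set. At this position on a double-bonded chain carbon, the added methoxy group and the altered substitution pattern together leave the step within the scatter. No available evidence bears on this result. The compounds shown leave open whether an amine or a carboxylic acid on this phenyl ring would give a step beyond the scatter. They also leave open whether this exchange would give a similar step on a different core.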